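The source may hold more compounds than are shown below. What is called first, only, known or untested is meant among the compounds shown, and "the series" means these compounds.

Measured so far in an ADME assay on cells (Hepatocyte, Mus musculus) for metabolic stability, with a stated time of 30 min; on this read-out higher numbers stand for a more stable compound and lower numbers for a less stable compound:

- compound 1 `CS(=O)(=O)NC1CCC(CN2CCN(c3cc(=O)c4cc(C(F)(F)F)cc([N+](=O)[O-])c4s3)CC2)CC1`: 111%
- compound 2 `O=c1cc(N2CCN(CC3CCCCC3)CC2)sc2c(NO)cc(C(F)(F)F)cc12`: 47.8%
- compound 3 `Nc1cc(C(F)(F)F)cc2c(=O)cc(N3CCN(CC4CCC(O)CC4)CC3)sc12`: 60%

Of these three, compound 2 stands lowest, at 47.8%. The nearest neighbour is compound 3, at 60%, and the furthest is compound 1, at 111%. Both gaps lie beyond the usual scatter of repeated measurements.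

The next compound to be tested is compound 4 `O=c1cc(N2CCN(CC3CCCCC3)CC2)sc2c([N+](=O)[O-])cc(C(F)(F)F)cc12`. It keeps everything in compound 2 except one group, with nitro in place of hydroxyamino on an aromatic carbon.

Among the measured compounds shown here, no measured pair here differs in only one place, so there is no direct precedent for this change. The nearest clue is compound 1, which also carries the nitro group and gives 111%. However, compound 1 also differs from compound 4 in another part of the molecule, so it is only a loose guide. It points upward, and a moderate rise in this assay is therefore expected, with real uncertainty about its size.

The estimated change is a number 17.2 percentage points higher from compound 2 to compound 4 (beyond the scatter).

For compound 4 the expected value is 65%, with an estimated range from 40% to 95%.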

Compound 4, percent of the compound remaining: 80.6%
Beside the measured number, compound 4's estimate is 15.6 percentage points below it, within the range that was stated.
By their numbers in this assay, from the lowest: compound 2; then compound 3; then compound 4; then compound 1.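

In this assay, among the compounds shown here, nitro in place of hydroxyamino on this aromatic carbon, meta to a trifluoromethyl group, gives a large rise of a number 32.8 percentage points higher from compound 2 to compound 4 (beyond the scatter) and is the first direct reading of this change with the rest of the molecule held constant. With nitro kept in this position, hydrogen in place of methanesulfonamido on a saturated ring carbon gives a large fall of a number 30.4 percentage points lower from compound 1 to compound 4 (beyond the scatter) and so shows that the number for a nitro compound in this set still depends on what the saturated ring carries. The data shown offer no measured explanation for either step.

On these data alone, compound 3 differs from both compound 2 and compound 4 in more than one place, so the standing of its amino group against hydroxyamino or nitro remains unread, and it remains open how a different group on this aromatic carbon, such as a nitrile or a carboxylic acid, would compare with nitro. As far as these compounds go, it is also open whether the methanesulfonamido group would shift the number in the same direction and by a similar amount with hydroxyamino on the aromatic carbon instead of nitro.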